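Chloro for methyl on the aryl lactam of compound 2

The compounds below may be only part of what the source reports. "The series", "measured", "known", "first", "only" and "open" are said of these compounds alone.

Compound 2 `Cc1cccc(N2CC(c3nc(-c4cccc(Cl)c4)no3)CC2=O)c1` gives 2300 nM in an in vitro functional assay on HEK293-A cells for negative allosteric modulation of metabotropic glutamate receptor 5 (Homo sapiens), read by FLIPR and calcium flux; on this read-out higher numbers stand for weaker inhibition and lower numbers for stronger inhibition. Compound 1 `C[C@H](c1ccccc1)N1C[C@H](c2nc(-c3cccc(Cl)c3)no2)CC1=O` gives 1600 nM in this assay, and the two numbers lie within the usual scatter of each other. Compound 3 `O=C1CC(c2nc(-c3cccc(Cl)c3)no2)CN1c1cccc(Cl)c1` has not yet been measured; it differs from compound 2 by chloro in place of methyl on an aromatic carbon, so the 3-methylphenyl becomes a 3-chlorophenyl. For the measured compounds named here, no measured pair shows this change, and the step of a 1.2-fold lower number from compound 2 to compound 3 (0.06 log units; within the scatter) is expected to stay within the scatter. Compound 3 is therefore estimated at 2000 nM, with a range from 800 nM to 5000 nM.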

Compound 3, half-maximal inhibitory concentration: 1100 nM
Beside the measured number, compound 3's estimate is 1.8-fold (0.26 log units) above it, and the stated range covers the measured number.
By their numbers in this assay, from the lowest: compounds 3, 1 and 2 (each within the scatter of the next, the first and the last beyond it).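

Chloro in place of methyl on this aromatic ring is the first single change that can be read in this series, and in this assay it gives a 2.1-fold lower number from compound 2 to compound 3 (0.32 log units; beyond the scatter). The step is modest, but it shows that the choice between these two small groups at this position can move the number beyond the scatter, with the 3-chlorophenyl giving the stronger inhibition. No supporting data bear on why the number falls. Going by these compounds, whether fluoro, methoxy or nitrile at the same position would lower the number further remains open. A single step also cannot show whether this gain would hold on a different core.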